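Changing the aryl ring on a dopamine receptor agonist series

The source may hold more compounds than are shown below. What is called first, only, known or untested is meant among the compounds shown, and "the series" means these compounds.

Of the compounds shown here, three built on one shared core have been tested in a functional assay on HEK293 cells for agonist activity at D(4) dopamine receptor (Homo sapiens), read by FLIPR; a higher number here means that more compound is needed for the effect, a lower number that less compound is needed. Compound 1 `O=C(CN1CCC(c2cccc[n+]2[O-])CC1)Nc1cccc(F)c1` gives 160 nM. Compound 2 `O=C(CN1CCC(c2cccc[n+]2[O-])CC1)Nc1cc(Cl)cc(Cl)c1` gives 160 nM, so the step of no change at the digits printed from compound 1 to compound 2 (within the scatter) leaves the number essentially where it was. Compound 3 `Cc1cc(Br)ccc1NC(=O)CN1CCC(c2cccc[n+]2[O-])CC1` gives 66 nM, the lowest of the three numbers; the step of a 2.4-fold lower number from compound 1 to compound 3 (0.38 log units; beyond the scatter) and the step of a 2.4-fold lower number from compound 2 to compound 3 (0.38 log units; beyond the scatter) are both modest, and the two older compounds sit the same distance away from compound 3.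

Compound 4 `CSc1cccc(NC(=O)CN2CCC(c3cccc[n+]3[O-])CC2)c1` has not yet been measured. It differs from compound 3 in one place: 3-(methylsulfanyl)phenyl in place of 4-bromo-2-methylphenyl on an amide-type nitrogen. The two steps that bear on this change, from compound 1 and from compound 2 to compound 3, each swapped one substituted phenyl for another on the same nitrogen, and each moved the number by only a modest amount. The entering 3-(methylsulfanyl)phenyl resembles the 3-fluorophenyl of compound 1 more than the ring of compound 3, so a drift back toward the number of compound 1 seems more likely than a further fall. Compound 4 is therefore expected to give about 130 nM, within a range from 50 nM to 400 nM. The expected step is a 2.0-fold higher number from compound 3 to compound 4 (0.29 log units; within the scatter).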

Compound 4, half-maximal effective concentration: 100 nM
The estimate for compound 4 lay 1.3-fold (0.11 log units) above the measured number; the measured number falls inside the stated range.
By their numbers in this assay, from the lowest: compounds 3, 4, 1 and 2 (each within the scatter of the next, the first and the last beyond it).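

In this assay, putting 3-(methylsulfanyl)phenyl on the amide-type nitrogen gives a 1.5-fold higher number from compound 3 to compound 4 (0.18 log units; within the scatter) and a 1.6-fold lower number from compound 2 to compound 4 (0.20 log units; within the scatter) as the two steps from the more heavily substituted rings, so this ring cannot be told apart from either of them. The smallest change in the set, a single swap of methylsulfanyl for fluoro on an aromatic carbon, gives a 1.6-fold lower number from compound 1 to compound 4 (0.20 log units; within the scatter) and so shows that a sulfur-bearing group can enter this part of the molecule without a step beyond the scatter, although compound 3 stands beyond the scatter from compound 1 and compound 2. Nothing shown here gives a measured reason for these numbers.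

Going by these compounds, the four compounds carry only halogen, methyl and methylsulfanyl groups on the phenyl ring, so it remains open whether an amine or a carboxylic acid there would produce a step beyond the scatter. On these data alone, it is equally open whether a longer chain on the sulfur, such as ethylsulfanyl, or a methylsulfonyl group in place of methylsulfanyl, would leave the number where it is.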